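The source may hold more compounds than are shown below. What is called first, only, known or untested is meant among the compounds shown, and "the series" means these compounds.

Measured so far in a functional assay on MDA-MB-468 cells (Homo sapiens) for inhibition; on this read-out lower numbers stand for stronger inhibition and higher numbers for weaker inhibition:
Compound 1, `CCc1cc(N)ccc1-c1nc2ccccc2s1`, gives < 0.1 nM; this is a limit of the assay, not a number.
Compound 2, `Cc1ccc2nc(-c3ccc(N)cc3Br)sc2c1`, gives < 0.1 nM; this too is a limit.
Compound 3, `Cc1ccc2nc(-c3ccc(N)cc3I)sc2c1`, gives < 0.1 nM; again a limit.

All three values sit at the limit of < 0.1 nM in this assay, at which 3 of the 3 values shown sit. Compound 1 therefore stands only as a limit in this assay, and the two further values shown are limits as well, so no order among compounds 1, 2 and 3 can be read from them. For the measured compounds named here, the only step between measured compounds that differ in one place, a step that the two limits leave unreadable from compound 2 to compound 3, is unreadable, since both of its ends sit at the limit of < 0.1 nM in this assay, at which 3 of the 3 values shown sit.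

Compound 4, `Nc1ccc(-c2nc3ccccc3s2)c(Cl)c1`, differs from compound 1 by chloro in place of ethyl on an aromatic carbon. Going by the values given here, no measured step bears directly on this change; the nearest is the bromo-to-iodo step between compound 2 and compound 3, whose size is not readable. With every neighbour at the limit, compound 4 is expected to report at or near the limit as well. The estimate for compound 4 in this assay is 0.08 nM, with a range from 0.02 nM to 0.4 nM. The step that the limit leaves unreadable from compound 1 to compound 4 is accordingly expected to be no larger than the usual scatter, in no clear direction.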

Compound 4, half-maximal inhibitory concentration: < 0.1 nM
Compound 4 ended at the assay's limit (the forecaster's own chance of this, stated with the estimate: 70%); the middle value is on the limit's open side.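

No new step can be read between compound 1 and compound 4, because both ends sit at a limit in this assay: the limit of < 0.1 nM in this assay, at which 4 of the 4 values shown sit.

The compounds shown leave open any order among compound 1, compound 2, compound 3 and compound 4, and whether chloro in place of ethyl on an aromatic carbon shifts inhibition at all.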